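Swapping methoxy for trifluoromethyl on a potent nicotinic ligand

This account rests on a few compounds, and the source may have more. Where it says the series, first, only, none or still open, it means among the compounds named here.

Three compounds that share a diazabicyclic amine joined to an aromatic core have been tested in an assay on cell membranes for displacement of a labelled ligand from Neuronal acetylcholine receptor; alpha4/beta2 (Rattus norvegicus); a lower number here means a stronger inhibitor, a higher number a weaker inhibitor. Compound 1 `COc1ccc(Nc2cncc(N3CC4CC(C3)N4)c2)cc1` gives 0.0598 nM, the lowest number of the three. Compound 2 `c1ccc(Nc2ccc(N3CC4CC(C3)N4)cn2)cc1` gives 2.66 nM, a gap from compound 1 that lies well beyond the scatter of the method. Compound 3 `O=[N+]([O-])c1ccc(Nc2ccc(N3CC4CC(C3)N4)nn2)cc1` gives 86.2 nM, further still from compound 1. No two of these three differ in only one place, so their gaps cannot be pinned on a single change.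

Compound 4 `FC(F)(F)c1ccc(Nc2cncc(N3CC4CC(C3)N4)c2)cc1` does differ from compound 1 in a single place: trifluoromethyl in place of methoxy on an aromatic carbon. Among the compounds with values here, nothing among the measured compounds shows how this particular swap behaves in this assay, so the size of the step is open. Because compound 1 sits at 0.0598 nM, an already very low number, a small loss seems more likely than a further gain. The step expected from the swap, a 5.0-fold higher number from compound 1 to compound 4 (0.70 log units; beyond the scatter), is a modest weakening, though one that could still fall within the scatter. Compound 4 is thus estimated at 0.3 nM in this assay, with a range from 0.05 nM to 2.5 nM.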

Compound 4, inhibition constant: 0.373 nM
Beside the measured number, compound 4's estimate is 1.2-fold (0.09 log units) below it, within the range that was stated.
By their numbers in this assay, from the lowest: compound 1; then compound 4; then compound 2; then compound 3.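

Placing trifluoromethyl in place of methoxy on an aromatic carbon, para to a large group, gives a 6.2-fold higher number from compound 1 to compound 4 (0.80 log units; beyond the scatter) in this assay, the first step in this set that can be tied to one change. This position therefore accepts a real change of group at a measurable but modest cost: methoxy, with its 1 hydrogen-bond acceptor, leaves, trifluoromethyl, with 0 hydrogen-bond acceptors and more heavy atoms, enters, and compound 4 still gives 0.373 nM. Nothing measured here explains why the step has this size, so the result records the change without giving its cause.

Within the data shown here, a single swap gives only one step at this position, so it cannot show whether the number follows any trend across different groups placed there. A plain hydrogen, an amine, a carboxylic acid or a longer chain such as ethoxy at the same place on the shared core would show whether methoxy is unusually favourable there or whether many groups give numbers in the same low range.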